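Methyl to cyano on selenium, carried to a second core

The source may report more compounds than this note shows. Statements on the series, on what has been measured and on what is new or still open speak of the compounds shown alone.

Compound 1 `C[Se]c1ccc(N(C)c2nc(C3CC3)nc3ccccc23)cc1` and compound 2 `COc1ccc(N(C)c2nc(C)nc3ccccc23)cc1[Se]C` both carry a methyl on selenium; the difference between their two cores is not broken down here. In a functional assay on MDA-MB-231 cells (Homo sapiens) for inhibition, read by MTT assay, with a stated time of 48 h (on this read-out lower numbers stand for stronger inhibition and higher numbers for weaker inhibition), compound 1 gives 18 nM, and compound 2 gives 10 nM, two numbers that sit within the usual scatter of each other. Compound 3 `COc1ccc(N(C)c2nc(C)nc3ccccc23)cc1[Se]C#N` is compound 2 with cyano in place of methyl on a selenium. In this assay compound 3 gives 52 nM, which is a 5.2-fold higher number from compound 2 to compound 3 (0.72 log units; beyond the scatter).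

Compound 4 `CN(c1ccc([Se]C#N)cc1)c1nc(C2CC2)nc2ccccc12` has not yet been measured. For the measured compounds named here, it is compound 1 with cyano in place of methyl on a selenium, the same change as the one from compound 2 to compound 3, made at a place described in the same words. Going by the values given here, only one measured instance of this change exists, so the expectation rests on a single pair. Among the compounds with values here, the step from compound 1 to compound 4 in this assay is expected to be a 4.7-fold higher number from compound 1 to compound 4 (0.67 log units; beyond the scatter), close to the earlier step, because the one measured instance of this change gave a 5.2-fold higher number from compound 2 to compound 3 (0.72 log units; beyond the scatter). Compound 4 is accordingly estimated at 85 nM in this assay, with a range from 35 nM to 210 nM that allows for the core of compound 1 not being the core of compound 2.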

Compound 4, half-maximal inhibitory concentration: 29 nM
Beside the measured number, compound 4's estimate is 2.9-fold (0.47 log units) above it; measured number below the stated range.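

In this assay, cyano in place of methyl on a selenium gives a 1.6-fold higher number from compound 1 to compound 4 (0.21 log units; within the scatter), so on the core of compound 1 this change does not move the number beyond the usual scatter. The size of the step did not carry over from one core to the other: the same change on two cores in this assay, a 5.2-fold higher number (0.72 log units; beyond the scatter) from compound 2 to compound 3 and a 1.6-fold higher number (0.21 log units; within the scatter) from compound 1 to compound 4, 3.2-fold (0.51 log units) apart, beyond the scatter of two such steps. This shows that, for these two pairs, a step measured on one core is a poor guide to the step on the other, but with a single pair on each core it does not show which of the differences between the cores goes with the gap, or how either step would look on a third core.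

Open, on these data alone, is whether an ethyl group or a longer chain on the selenium would keep numbers close to those of compound 1 and compound 2. Also open, as far as these compounds go, is how the change behaves on a compound that differs from either core in only one place.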